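The compounds below may be only part of what the source reports. "The series", "measured", "known", "first", "only" and "open" are said of these compounds alone.

Measured so far in a physicochemical assay for lipophilicity; a higher number here means a more lipophilic compound, a lower number a more polar compound:

compound 1 `Cn1nccc1-c1cc(C(F)(F)F)ccc1[C@H]1CCOc2cc(S(=O)(=O)Nc3cccc(F)n3)ccc21` — 3.6
compound 2 `O=S(=O)(Nc1ncccn1)c1ccc2c(c1)OCC[C@@H]2c1ccc(C(F)(F)F)cc1-c1ccc(F)cn1` — 2.9
compound 3 `Cc1nc(-c2cc(C(F)(F)F)ccc2[C@H]2CCOc3cc(S(=O)(=O)Nc4cccc(F)n4)ccc32)co1` — 4

Compound 1 stands second highest of the three numbers in this assay; its nearest neighbour is compound 3, a number 0.40 log units higher from compound 1 to compound 3 (beyond the scatter), and the furthest is compound 2, whose value lies lower than that of compound 1 by more than the scatter. Compound 2 differs from compound 1 in more than one place, so only its value is noted here.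

The next compound, compound 4 `Cn1nccc1-c1cc(C(F)(F)F)ccc1[C@H]1CCOc2cc(S(=O)(=O)Nc3ccc(F)cn3)ccc21`, differs from compound 1 by a single change: 5-fluoropyridin-2-yl in place of 6-fluoropyridin-2-yl on a sulfonamide nitrogen. Going by the values given here, no measured step bears directly on this change; the one step recorded, from compound 1 to compound 3, concerns a group on an aromatic carbon elsewhere in the molecule, and the atoms of compounds 1 and 4 are the same, merely joined differently. In the absence of a relevant step, no movement beyond the scatter is expected in this assay, so no change at the digits printed from compound 1 to compound 4 (within the scatter) is the estimated step. Compound 4 is therefore expected to give about 3.6 in this assay, within a range of 3.2 to 4.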

Compound 4, distribution coefficient: 3.8
Compound 4: middle estimate off by 0.20 log units, on the low side, within the range that was stated.
By their numbers in this assay, from the lowest: compound 2; then compounds 1, 4 and 3 (each within the scatter of the next, the first and the last beyond it).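

In this assay, going by these compounds alone, the first reading at this position, with 5-fluoropyridin-2-yl in place of 6-fluoropyridin-2-yl on a sulfonamide nitrogen, is a number 0.20 log units higher from compound 1 to compound 4 (within the scatter) and concerns two groups of identical atom content. On the core of compound 1, these two fluoropyridinyl groups are therefore not separated by this read-out, unlike the groups on an aromatic carbon in the earlier step, which gave a number 0.40 log units higher from compound 1 to compound 3 (beyond the scatter) and stands beyond the scatter. No measurement available here accounts for the result on the sulfonamide nitrogen.

Open, as far as these compounds go, is whether an unsubstituted pyridin-2-yl, or a pyridin-2-yl carrying chlorine or methoxy, would give a step beyond the scatter at this nitrogen. Also open, from the compounds shown here alone, is whether the 5-fluoropyridin-2-yl for 6-fluoropyridin-2-yl exchange reads the same alongside the 2-methyl-1,3-oxazol-4-yl group of compound 3.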